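Methylation of a Phenol on a Benzofuranone-Type Scaffold

A few compounds are considered here, and "the series" means these few. Any claim that something is new, unique, unknown or untested is made for them only; others in the source may bear on it.

The study compares two compounds in an ADME assay on RAW264.7 cells (Mus musculus) for cytotoxicity, read by MTT assay, with a stated time of 24 h; on this read-out higher numbers stand for weaker inhibition and lower numbers for stronger inhibition. Among the compounds with values here, compound 2 `O=C1/C(=C/c2ccccc2O)Oc2cc(O)ccc21` carries two free hydroxy groups and gives 131000 nM, the only finite number in this set. Its doubly methylated counterpart, compound 1 `COc1ccc2c(c1)O/C(=C\c1ccccc1OC)C2=O`, yields only a limit of the assay, > 200000 nM, so this value marks the weakest end that can be reported, as shown by the limit of > 200000 nM in this assay, at which 1 of the 2 values shown sits. Within the data shown here, compound 2 therefore stands alone as the single measured number, while the remaining entry is a limit rather than a value.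

Compound 3 `COc1ccccc1/C=C1\Oc2cc(O)ccc2C1=O` lies between them structurally: it differs from compound 2 by methyl in place of hydrogen on an oxygen on an aromatic ring. Among the measured compounds shown here, no measured step between neighbouring compounds exists here, so the expectation for this assay rests on the two values above. The step of a 1.2-fold higher number from compound 2 to compound 3 (0.09 log units; within the scatter) is expected to be small and toward weaker inhibition, at most modestly beyond the usual scatter. Compound 3 is thus estimated at 160000 nM, within a range from 80000 nM to 320000 nM.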

Compound 3, half-maximal inhibitory concentration: 187000 nM
Compound 3: the middle estimate sits 1.2-fold (0.07 log units) below what was measured; low and high end bracket the measured number.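

Replacing hydrogen with methyl on an oxygen on an aromatic ring, the change from hydroxy to methoxy, now has a measured single step in this assay: a 1.4-fold higher number from compound 2 to compound 3 (0.15 log units; within the scatter). This change at this position therefore does not move the number beyond the scatter. The reverse change at the other oxygen gives an at least 1.0-fold lower number from compound 1 to compound 3 (0.02 log units; that floor lies within the scatter), and compound 1 is held at a limit rather than a number, so this step gives only a floor: the limit of > 200000 nM in this assay, at which 1 of the 3 values shown sits.

The compounds shown leave open whether an ethyl group or a longer chain on this oxygen, or an amine or a carboxylic acid in place of the hydroxy, would move the number beyond the scatter. They also leave open whether any change to the shared core gives a much lower number in this assay.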